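The source may hold more compounds than are shown below. What is called first, only, known or untested is meant among the compounds shown, and "the series" means these compounds.

Working notes on the series. Among the compounds with values here, in an ADME assay (liver) for metabolic stability, with Liver microsome (Homo sapiens) as the target, using microsomes (a higher number here means faster removal of the compound, a lower number slower removal), compound 1 `c1ccc([C@H](Nc2nnc(-c3c[nH]c4ncccc34)o2)C2CC2)cc1` gives 56 mL.min-1.g-1 and compound 2 `Fc1ncccc1[C@H](Nc1nnc(-c2c[nH]c3ncccc23)o1)C1CC1` gives 21 mL.min-1.g-1, so compound 2 holds the lower of the two numbers so far. Compound 3 `Fc1ccc2c(-c3nnc(N[C@@H](c4cccnc4F)C4CC4)o3)c[nH]c2n1` differs from compound 2 by fluoro in place of hydrogen on an aromatic carbon, next to the ring nitrogen, in a six-membered aromatic ring with 1 nitrogen that is part of a fused or bridged system of two rings. Within the data shown here, the only measured step is a 2.7-fold lower number from compound 1 to compound 2 (0.43 log units; beyond the scatter), a modest one, made elsewhere in the molecule by 2-fluoropyridin-3-yl in place of phenyl. Among the measured compounds shown here, it bears only loosely on this change, and no measured step covers this place. No shift beyond the scatter is therefore expected in this assay. The estimated step is a 1.2-fold lower number from compound 2 to compound 3 (0.07 log units; within the scatter). The expected value for compound 3 is 18 mL.min-1.g-1, with an estimated range from 9 mL.min-1.g-1 to 36 mL.min-1.g-1.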

Compound 3, intrinsic clearance in microsomes: < 14 mL.min-1.g-1
Compound 3: only a limit was reported; the forecaster's own chance of this, stated with the estimate: 2%; at least 1.2-fold (0.10 log units) between middle value and limit.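

In this assay compound 3 gives < 14 mL.min-1.g-1, which is a limit of the assay and not a number. Fluoro in place of hydrogen on the aromatic carbon next to the ring nitrogen gives an at least 1.5-fold lower number from compound 2 to compound 3 (0.17 log units; that floor lies within the scatter), the first reading at this place, as the earlier step lay elsewhere in the molecule. That floor does not establish a shift beyond the scatter, and the full size of the step cannot be read: the limit of < 14 mL.min-1.g-1 in this assay, at which 1 of the 3 values shown sits.

Going by these compounds, whether a different group at this place, such as chloro, methoxy or an amine, would give a comparable number remains open. Also open, on these data alone, is whether the same fluoro change would give a comparable step with phenyl in place of 2-fluoropyridin-3-yl, as in compound 1.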